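Two Close Values and an Added Methyl

The compounds below may be only part of what the source reports. "The series", "measured", "known", "first", "only" and "open" are said of these compounds alone.

Compound 1 `CC(C)OCc1cc(CN2CCCCC2)c(O)c2ncccc12`: 5750 nM
Compound 2 `CCOCc1cc(CN2CCC(C)CC2)c(O)c2ncccc12`: 4470 nM

Both values come from a functional assay on MES-SA cells (Homo sapiens) for inhibition, with a stated time of 72 h, in the presence of a further agent that is not named here; a higher number here means a weaker inhibitor, a lower number a stronger inhibitor. There, compound 2 at 4470 nM stands level with compound 1 at 5750 nM, within the usual scatter of repeated measurements, so the two cannot be ranked. The next compound is compound 3 `CC1CCN(Cc2cc(COC(C)C)c3cccnc3c2O)CC1`, which turns the ethoxymethyl group of compound 2 into isopropoxymethyl: methyl in place of hydrogen on a saturated chain carbon bound to an oxygen on a saturated carbon and a saturated chain carbon. Within the data shown here, no measured pair shows this change alone, so its size is not known directly. Compound 1 already carries isopropoxymethyl and gives 5750 nM, which offers no sign of a large shift, and no step beyond the scatter is expected in this assay. The estimated change is a 1.1-fold higher number from compound 2 to compound 3 (0.03 log units; within the scatter). For compound 3 the expected value is 4800 nM, with an estimated range from 2400 nM to 9500 nM.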

Compound 3, half-maximal inhibitory concentration: 3020 nM
Estimate against measurement, compound 3: 1.6-fold (0.20 log units) above; measured number inside the range.
By their numbers in this assay, from the lowest: compounds 3, 2 and 1 (each within the scatter of the next).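

In this assay, the change from ethoxymethyl to isopropoxymethyl can now be read directly, as a 1.5-fold lower number from compound 2 to compound 3 (0.17 log units; within the scatter), so this methyl on the saturated chain carbon does not separate the two compounds. Among these compounds, the same compound also gives a first reading of a second place, methyl in place of hydrogen on a saturated ring carbon, as a 1.9-fold lower number from compound 1 to compound 3 (0.28 log units; within the scatter), and this step does not separate its two compounds either. Nothing measured here bears on the reason for either result.

The compounds shown leave open whether a longer chain on the oxygen, such as butyl, or an amine in place of the isopropoxy group would give a step beyond the scatter. On these data alone, each methyl step rests on a single pair, so it also remains open whether either would hold on other compounds.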